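The compounds below may be only part of what the source reports. "The series", "measured", "known", "first", "only" and "open" are said of these compounds alone.

Compound 1 `Cc1ccc2cccc(NC(=O)c3cnccn3)c2n1` and compound 3 `Cc1ccc2cccc(NC(=O)c3ncccn3)c2n1` share one core; compound 2 `O=C(Nc1cc(F)cc2cccnc12)c1cnccn1` and compound 4 `O=C(Nc1cc(F)cc2cccnc12)c1ncccn1` share another, and the difference between the two cores is not broken down here. In a functional assay on PANC-1 cells (Homo sapiens) for inhibition, read by MTT assay, with a stated time of 72 h (a lower number here means a stronger inhibitor, a higher number a weaker inhibitor), compound 1 gives > 10000 nM, a limit of the assay. Compound 3 gives > 10000 nM, also a limit. The change from compound 1 to compound 3 is pyrimidin-2-yl in place of pyrazin-2-yl on a carbonyl carbon; the step that the two limits leave unreadable from compound 1 to compound 3 stays unreadable because of the limit of > 10000 nM in this assay, at which 2 of the 3 values shown sit. Among the measured compounds shown here, compound 2 gives 670 nM, the only number in the set. Compound 4 carries the same change, (pyrimidin-2-yl in place of pyrazin-2-yl on a carbonyl carbon). The measured pair gives no readable size for it, and the expectation for compound 4 rests on compound 2 at 670 nM alone. For compound 4 the expected step is a 2.2-fold higher number from compound 2 to compound 4 (0.35 log units; beyond the scatter). Compound 4 is estimated at 1500 nM, expected between 400 nM and 8000 nM.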

Compound 4, half-maximal inhibitory concentration: 5300 nM
The estimate for compound 4 lay 3.5-fold (0.55 log units) below the measured number; measured number inside the range.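

In this assay, pyrimidin-2-yl in place of pyrazin-2-yl on a carbonyl carbon gives a 7.9-fold higher number from compound 2 to compound 4 (0.90 log units; beyond the scatter) on the core of compound 2. The same change from compound 1 to compound 3 cannot be read, because both compounds sit at a limit of the assay: the limit of > 10000 nM in this assay, at which 2 of the 4 values shown sit.

The direction and size of the change are thus seen on one core only, and carry-over from one core to the other is not shown.

Still open, from the compounds shown here alone, is how pyridin-2-yl or phenyl on the same carbonyl carbon would compare with pyrazin-2-yl on the core of compound 2. Also open, going by these compounds, is whether an amine on the pyrazin-2-yl ring would bring the core of compound 1 into the readable range.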